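Swapping the aminophenyl of compound 2 for a dichlorophenyl

This account rests on a few compounds, and the source may have more. Where it says the series, first, only, none or still open, it means among the compounds named here.

Compounds measured so far:
- compound 1, `COc1ccc(-c2cc(/C=C/C(=O)c3ccc(N)cc3)[nH]n2)cc1`: 5300 nM
- compound 2, `COc1cc(-c2cc(/C=C/C(=O)c3ccc(N)cc3)[nH]n2)cc(OC)c1OC`: 5390 nM

Both compounds were tested in a functional assay on U-251 cells (Homo sapiens) for inhibition, read by sulforhodamine B assay, with a stated time of 48 h; a higher number here means that more compound is tolerated, a lower number that less compound is tolerated. In this assay compound 1 gives 5300 nM and compound 2 gives 5390 nM. Compound 2 holds the higher of the two numbers, but the gap to compound 1 is tiny and lies within the scatter of repeated measurements, so the two compounds cannot be told apart on these data.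

Compound 3, `COc1cc(-c2cc(/C=C/C(=O)c3ccc(Cl)c(Cl)c3)[nH]n2)cc(OC)c1OC`, has not yet been measured. It differs from compound 2 in one place: 3,4-dichlorophenyl in place of 4-aminophenyl on a carbonyl carbon. A group carrying a hydrogen-bond donor and acceptor is thus replaced by one carrying two chlorine atoms and neither.

Going by the values given here, no measured pair shows the effect of such a swap, so there is no step to lean on. In this assay the change from compound 2 to compound 3 is expected to be modest, a 1.3-fold lower number from compound 2 to compound 3 (0.13 log units; within the scatter), possibly toward a somewhat lower number, but not clearly beyond the scatter. Compound 3 is therefore estimated at 4000 nM, with a likely range from 1500 nM to 12000 nM.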

Compound 3, concentration lethal to 50% of the cells: > 100000 nM
Compound 3: a limit, no number (the forecaster's own chance of this, stated with the estimate: 10%); at least 25-fold (1.39 log units) between middle value and limit.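

Both earlier compounds carry the 4-aminophenyl on the carbonyl carbon, so they could not show whether this position matters; the swap to 3,4-dichlorophenyl shows that it does, with an at least 18-fold higher number from compound 2 to compound 3 (1.26 log units; beyond the scatter) in this assay. Compound 3 gives a limit of the assay and not a number, so the step has a lower bound but no known full size: the limit of > 100000 nM in this assay, at which 1 of the 3 values shown sits. The swap removes a hydrogen-bond donor and a hydrogen-bond acceptor and brings in two chlorine atoms, and this single step cannot tell whether losing the amine, gaining the chlorines, or both accounts for the change.

The compounds shown leave open whether a plain phenyl, a hydroxyphenyl or a phenyl with a single chlorine at this position would stay close to compound 2 or move toward compound 3. From the compounds shown here alone, it also remains open whether the same 3,4-dichlorophenyl swap would have a similar effect on compound 1, which has one methoxy group on its other aromatic ring.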